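Cyano in place of hydrogen on compound 2

This account rests on a few compounds, and the source may have more. Where it says the series, first, only, none or still open, it means among the compounds named here.

- compound 1 `CCn1c([C@@H](C)NS(=O)(=O)c2ccc(Cl)cc2)nc2ccccc21`: > 100 mL.min-1.g-1 (a limit of the assay, not a number)
- compound 2 `CCn1c([C@@H](C)NS(=O)(=O)c2ccccc2)nc2ccc(C(F)(F)F)cc21`: 14 mL.min-1.g-1

The series is read in an ADME assay (liver) for metabolic stability, with Liver microsome (Homo sapiens) as the target, read by LC-MS, using microsomes and NADPH, with a stated time of 5 min, at 37 degrees C; a higher number here means faster removal of the compound, a lower number slower removal. In this assay, among the compounds with values here, compound 2 gives 14 mL.min-1.g-1, the only true number so far. Compound 1 reports only a limit. The two measured compounds differ in more than one place, so their readings isolate no single structural change.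

The next compound is compound 3 `CCn1c([C@@H](C)NS(=O)(=O)c2cccc(C#N)c2)nc2ccc(C(F)(F)F)cc21`. It carries cyano in place of hydrogen on an aromatic carbon, meta to a large group, taking phenyl to 3-cyanophenyl (cyano in place of hydrogen on an aromatic carbon). Within the data shown here, no measured pair shows this change, so the expectation is anchored only on compound 2 at 14 mL.min-1.g-1. Without a measured guide, a small step is expected, with no clear direction and probably none beyond the usual scatter. The expected change is a 1.2-fold lower number from compound 2 to compound 3 (0.07 log units; within the scatter). For compound 3 the estimated value is 12 mL.min-1.g-1, with an expected range of 6 mL.min-1.g-1 to 26 mL.min-1.g-1.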

Compound 3, intrinsic clearance in microsomes: > 100 mL.min-1.g-1
Compound 3: only a limit was reported; the forecaster's own chance of this, stated with the estimate: 3%; middle value at least 8.3-fold (0.92 log units) away from the limit.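

Within the data shown here, the step of an at least 7.1-fold higher number from compound 2 to compound 3 (0.85 log units; beyond the scatter) in this assay is the first single change that can be read, and it shows that this aromatic carbon of the phenyl ring of compound 2 is not neutral to substitution. Compound 3 gives > 100 mL.min-1.g-1, which is a limit of the assay and not a number, so the step has a lower bound and no upper one. Among these compounds, compound 2 remains the only compound with a true number, so any further change at this position can be sized only if its value falls under that limit: the limit of > 100 mL.min-1.g-1 in this assay, at which 2 of the 3 values shown sit.

From the compounds shown here alone, whether the step belongs to the cyano group itself or would follow any group at this carbon remains open, and a fluorine, a methoxy or an amine in the same place would separate those two readings. Also unsettled is whether the same cyano group on another carbon of the phenyl ring would give a step of similar size, and the compounds shown offer no comparison on that point.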